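The source may hold more compounds than are shown below. What is called first, only, known or untested is meant among the compounds shown, and "the series" means these compounds.

In an ADME assay on HepG2 cells (Homo sapiens) for cytotoxicity, read by CellTiter-Glo and resazurin assay, with a stated time of 72 h (on this read-out lower numbers stand for an effect already at smaller amounts and higher numbers for an effect only at larger amounts of compound), compound 1 `CCOC(=O)CCCCCOc1cccc(CN(C(=O)c2ccc(-c3cccc(NC(C)=O)c3)cc2)C(C)C)c1` gives only a limit, > 26000 nM. Compound 2 `CCOC(=O)CCCCCOc1cccc(CN(C(=O)c2ccc(-c3cnc(OC)nc3OC)cc2)C(C)C)c1` likewise reaches only the limit, > 26000 nM. Compound 3 `CCOC(=O)CCCCCOc1cccc(CN(C(=O)c2ccc(-c3cccc(OCC(C)C)c3)cc2)C(C)C)c1` also gives nothing but the limit, > 26000 nM. So compound 3 stands where every compound shown stands: at the limit of > 26000 nM in this assay, at which 3 of the 3 values shown sit, with no number of its own. The three steps among these compounds, a step that the two limits leave unreadable from compound 1 to compound 2, a step that the two limits leave unreadable from compound 1 to compound 3 and a step that the two limits leave unreadable from compound 2 to compound 3, therefore cannot be read; whether swapping one aryl group for another moved the cytotoxicity at all is hidden behind the limit.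

Compound 4 `CCOC(=O)CCCCCOc1cccc(CN(C(=O)c2ccc(-c3cccc(-c4nnc(C)o4)c3)cc2)C(C)C)c1` is the next member. Its change from compound 3 is 5-methyl-1,3,4-oxadiazol-2-yl in place of isobutoxy on an aromatic carbon; seen from one bond further out, 3-(isobutoxy)phenyl becomes 3-(5-methyl-1,3,4-oxadiazol-2-yl)phenyl. Within the data shown here, none of the measured steps gives a readable size to go by, so no direction can be claimed; the expectation is simply that compound 4 also sits beyond the limit. The estimate for compound 4 is 40000 nM, ranging from 20000 nM to 120000 nM. That expected outcome corresponds to a step that the limit leaves unreadable from compound 3 to compound 4, which is no change beyond the scatter.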

Compound 4, half-maximal effective concentration: > 26000 nM
Compound 4 was reported as a limit (the forecaster's own chance of this, stated with the estimate: 85%); the middle value does not contradict the limit.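

In this assay compound 4 gives > 26000 nM as a limit and not a number. Its steps from compound 1, compound 2 and compound 3 therefore cannot be read. Whether any of these swapped groups moves the cytotoxicity at all stays open, since every value shown sits in one place: the limit of > 26000 nM in this assay, at which 4 of the 4 values shown sit.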